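A few compounds are considered here, and "the series" means these few. Any claim that something is new, unique, unknown or untested is made for them only; others in the source may bear on it.

Measured so far in a functional assay on the whole organism for inhibition, with Rattus norvegicus as the target; a higher number here means that more compound is needed for the effect, a lower number that less compound is needed:

Compound 1, `N#Cc1cccnc1N1CCN(CCCCN2C(=O)SC3(CCCC3)C2=O)CC1`: in this assay compound 1 gives 29.3 mg/kg.
Compound 2, `O=C1SC2(CCCC2)C(=O)N1CCCCN1CCN(c2ncccc2[N+](=O)[O-])CC1`: in this assay compound 2 gives 43.6 mg/kg.
Compound 3, `COc1cccnc1N1CCN(CCCCN2C(=O)SC3(CCCC3)C2=O)CC1`: for compound 3 this assay gives a limit, not a number: < 57 mg/kg.

Among the two numbers known, compound 1 has the lower one, and the nearest value belongs to compound 2, the change being a 1.5-fold higher number from compound 1 to compound 2 (0.17 log units; within the scatter); within the scatter no order between these two compounds can be read. The third value is only a limit (the limit of < 57 mg/kg in this assay, at which 1 of the 3 values shown sits), so the step that the limit leaves unreadable from compound 1 to compound 3 cannot be sized.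

The unmeasured compound 4, `O=C1SC2(CCCC2)C(=O)N1CCCCN1CCN(c2ncccc2Cl)CC1`, differs from compound 1 in one place: chloro in place of cyano on an aromatic carbon. Among the measured compounds shown here, no measured step exchanges cyano for chloro, so nothing bears on this change directly. The closest comparison is the exchange of cyano for nitro at the same place, which moved the number by a 1.5-fold higher number from compound 1 to compound 2 (0.17 log units; within the scatter), a step within the scatter. On that basis the step of a 1.1-fold higher number from compound 1 to compound 4 (0.04 log units; within the scatter) is expected to stay within the scatter as well, in no clear direction. Compound 4 is therefore estimated at 32 mg/kg in this assay, with a range from 13 mg/kg to 80 mg/kg.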

Compound 4, dose for half-maximal effect: 50 mg/kg
The estimate for compound 4 lay 1.6-fold (0.19 log units) below the measured number; measured number inside the range.
By their numbers in this assay, from the lowest: compounds 1, 2 and 4 (each within the scatter of the next).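

In this assay, the exchange of 3-cyanopyridin-2-yl for 3-chloropyridin-2-yl gives a 1.7-fold higher number from compound 1 to compound 4 (0.23 log units; within the scatter), and the exchange of nitro for chloro at the same place gives a 1.1-fold higher number from compound 2 to compound 4 (0.06 log units; within the scatter). Together with the earlier nitro compound, this means that compounds 1, 2 and 4 all lie within the scatter of one another, so no order among these groups can be read at this place on the ring, even though chloro differs from cyano in its count of heavy atoms and of hydrogen-bond acceptors. Compound 3, which carries methoxy at this place, gives only a limit, so none of its steps to the other compounds can be read: the limit of < 57 mg/kg in this assay, at which 1 of the 4 values shown sits.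

Going by these compounds, what an amine or a carboxylic acid at this place on the ring would do to the number remains open, and so does whether any group here can move it beyond the scatter. Also open, on these data alone, is whether these three groups would stay this close with a longer chain attached to the core of compound 1.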